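A Methyl Added to a Weak Mast Cell Activator

A few compounds are considered here, and "the series" means these few. Any claim that something is new, unique, unknown or untested is made for them only; others in the source may bear on it.

In a functional assay on cells (Mast cell, Rattus norvegicus, strain Wistar) for activation, read by fluorescence, with a stated time of 15 min (a higher number here means that more compound is needed for the effect, a lower number that less compound is needed), compound 1 (`CCCCCCCCCCCCCCCCCC(=O)OCCOP(=O)(O)OC[C@H](N)C(=O)O`) gives > 10000 nM, which is a limit of the assay and not a number. Two relatives are measured: compound 2 (`CCCCCCCCCCCCCCCCCC(=O)NC[C@@H](O)COP(=O)(O)OC[C@H](N)C(=O)O`) gives 5000 nM, and compound 3 (`CCCCCCCCCCCCCCCCCC(=O)N(C)C[C@@H](O)COP(=O)(O)OC[C@H](N)C(=O)O`) gives 10000 nM. Compound 4 (`CCCCCCCCCCCCCCCCCC(=O)O[C@H](C)COP(=O)(O)OC[C@H](N)C(=O)O`) has methyl in place of hydrogen on a saturated chain carbon bound to an oxygen next to a carbonyl group and a saturated chain carbon. Among the compounds with values here, the only measured methyl step, a 2.0-fold higher number from compound 2 to compound 3 (0.30 log units; within the scatter), lies within the scatter, though it sits on an amide-type nitrogen, so it is only a loose guide. No step beyond the scatter is therefore expected in this assay, and the estimated change is a number no higher from compound 1 to compound 4 (the limit leaves the size open). For compound 4 the expected value is 10000 nM, with an estimated range of 3000 nM to 30000 nM.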

Compound 4, half-maximal effective concentration: > 10000 nM
Compound 4 was reported as a limit; the forecaster's own chance of this, stated with the estimate: 50%; the middle value sits exactly at the limit.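

Compound 1 and compound 4 are both reported as limits, not numbers, so no step can be read between them, because both sit at the same limit: the limit of > 10000 nM in this assay, at which 2 of the 4 values shown sit. The compounds shown leave open whether methyl in place of hydrogen at this place changes activation at all.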